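The compounds below may be only part of what the source reports. "The series", "measured", "known", "first", "only" and "open" are said of these compounds alone.

Of the compounds shown here, two have so far been measured in an assay (Equus caballus) for inhibition of Thromboxane-A synthase (Homo sapiens), using microsomes; a lower number here means a stronger inhibitor, a higher number a weaker inhibitor. Compound 1 `O=C(O)C(CCC/C=C(/c1cccnc1)c1cccs1)c1ccccc1` gives 32 nM in this assay. Compound 2 `NC(=O)CCCC/C=C(\c1ccccc1)c1cccnc1` gives 400 nM in this assay, the higher of the two numbers, and the gap to compound 1 lies beyond the usual scatter of repeated measurements. Going by the values given here, since compound 1 and compound 2 differ in more than one place, their two values show only that compound 1 reads much lower; they do not tell which part of the structure carries that difference.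

Compound 3 `C=C(C)C(CCC/C=C(\c1ccccc1)c1cccnc1)C(=O)O` has not yet been measured. It keeps the core of compound 2 and differs from it in a single place: 1-carboxy-2-methylprop-2-en-1-yl in place of carbamoylmethyl on a saturated chain carbon, three bonds along the chain from a double-bonded chain carbon. In plain terms, the primary amide at the end of the chain gives way to a carboxylic acid that carries a small branched alkene on the same chain carbon.

Among the compounds with values here, the only guide is compound 1, which also ends in a carboxylic acid and gives 32 nM. On that basis, compound 3 is expected to move toward that value, and the step of a 6.7-fold lower number from compound 2 to compound 3 (0.82 log units; beyond the scatter) is estimated to be a fall beyond the scatter. Compound 3 is estimated at 60 nM, with a likely range from 15 nM to 250 nM.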

Compound 3, half-maximal inhibitory concentration: 28 nM
Estimate against measurement, compound 3: 2.1-fold (0.33 log units) above, and the stated range covers the measured number.
By their numbers in this assay, from the lowest: compounds 3 and 1 (each within the scatter of the next); then compound 2.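

Going by these compounds alone, with the core held fixed, replacing carbamoylmethyl with 1-carboxy-2-methylprop-2-en-1-yl gives in this assay a 14-fold lower number from compound 2 to compound 3 (1.15 log units; beyond the scatter) and is the first change here that can be read at a single place. The earlier gap between compound 1 and compound 2 could not be assigned to any one part of the structure, whereas this step shows that a change at this chain position alone is enough to move the number well beyond the scatter. The swap is still a compound change, since the primary amide gives way to a carboxylic acid and a branched alkene appears on the same chain carbon, while the counted hydrogen-bond donors and acceptors stay the same.

The compounds shown leave open how much of the step belongs to the carboxylic acid and how much to the branch, which a simple unbranched carboxylic acid or a methyl ester at this position could help separate. No measurement beyond these potency numbers bears on why the number falls at this position.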